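Ring to Chain at the Carbamate Oxygen: Expecting Little Change

The source may hold more compounds than are shown below. What is called first, only, known or untested is meant among the compounds shown, and "the series" means these compounds.

Of the compounds shown here, three built on one shared core have been tested in a functional assay on MCF7 cells (Homo sapiens) for cytotoxicity, read by MTT assay, with a stated time of 72 h; a lower number here means that less compound is tolerated, a higher number that more compound is tolerated. Compound 1 `N#C[Se]c1ccc(NC(=O)OCc2ccc([N+](=O)[O-])cc2)cc1` gives 69500 nM. Compound 2 `N#C[Se]c1ccc(NC(=O)OCc2ccccc2)cc1` gives 68900 nM, and compound 3 `Cc1ccc(OC(=O)Nc2ccc([Se]C#N)cc2)cc1` gives 69800 nM. Among the compounds with values here, the one single-point step among them, a 1.0-fold lower number from compound 1 to compound 2 (0.00 log units; within the scatter), left the number unchanged. Compound 2 holds the lowest of the three numbers, yet its distances to compound 1 and to compound 3 both fall within the scatter, so all three compounds stand together at one level.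

Compound 4 `CCCCOC(=O)Nc1ccc([Se]C#N)cc1` is not yet measured. It differs from compound 2 by propyl in place of phenyl on a saturated chain carbon bound to an oxygen next to a carbonyl group. Within the data shown here, no measured step touches this part of the molecule; the only measured step concerns a different group and was flat. With nothing pointing either way, the expectation is no step beyond the scatter, so a 1.0-fold higher number from compound 2 to compound 4 (0.01 log units; within the scatter) is the estimated change. Compound 4 is therefore expected to give 70000 nM, with a range from 35000 nM to 140000 nM.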

Compound 4, concentration lethal to 50% of the cells: 59700 nM
Beside the measured number, compound 4's estimate is 1.2-fold (0.07 log units) above it; the measured number falls inside the stated range.
By their numbers in this assay, from the lowest: compounds 4, 2, 1 and 3 (each within the scatter of the next).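

In this assay, putting propyl in place of phenyl on a saturated chain carbon bound to an oxygen next to a carbonyl group gives a 1.2-fold lower number from compound 2 to compound 4 (0.06 log units; within the scatter) and so stays within the scatter. Within the data shown here, this is the first measured change at this position: the earlier step altered only a nitro group on the ring, whereas here the whole aromatic ring gives way to a smaller open chain and the compounds still stand at one level. Nothing at hand explains this tolerance of the exchange.

So far, no change at this position has moved the number beyond the scatter, so it remains open whether this position matters to the read-out at all. A longer chain, an amine or a carboxylic acid in place of the propyl could show whether the level holds for groups of a different kind.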